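The compounds below may be only part of what the source reports. "The series", "measured", "known", "first", "only" and "open" are said of these compounds alone.

Working notes on the bis(trifluoromethyl)benzenesulfonamide series.

Compound 1 `COc1ccc(CNCCCNS(=O)(=O)c2cc(C(F)(F)F)cc(C(F)(F)F)c2)cc1OC` gives 6400 nM in a functional assay on ASPC1 cells (Homo sapiens) for inhibition, read by MTT assay, with a stated time of 72 h; a lower number here means a stronger inhibitor of growth, a higher number a weaker inhibitor of growth. Compound 2 `O=S(=O)(NCCCNCc1ccc(Br)cc1)c1cc(C(F)(F)F)cc(C(F)(F)F)c1` gives 2800 nM in this assay; the step of a 2.3-fold lower number from compound 1 to compound 2 (0.36 log units; beyond the scatter) is the only measured one in the set. Among the measured compounds shown here, on these two numbers compound 2 holds the lower value, with compound 1 as its sole neighbour at that step's distance.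

Compound 3 `O=S(=O)(NCCCNCc1ccc(Cl)cc1)c1cc(C(F)(F)F)cc(C(F)(F)F)c1` differs from compound 2 only in that (chloro in place of bromo on an aromatic carbon). For the measured compounds named here, the single measured step bears on it only loosely: it exchanged the whole substitution pattern of the benzyl ring, whereas here one halogen replaces another at the same position. Going by the values given here, no measured pair in the set isolates such a halogen swap, so no step beyond the scatter is expected in this assay.

Compound 3 is therefore expected to give about 3500 nM in this assay, within 1500 nM to 8000 nM, a step of a 1.3-fold higher number from compound 2 to compound 3 (0.10 log units; within the scatter).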

Compound 3, concentration for 50% growth inhibition: 3000 nM
The estimate for compound 3 lay 1.2-fold (0.07 log units) above the measured number; measured number inside the range.
By their numbers in this assay, from the lowest: compounds 2 and 3 (each within the scatter of the next); then compound 1.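

On the aromatic carbon para to a large group, chloro in place of bromo separates nothing in this assay (the step is a 1.1-fold higher number from compound 2 to compound 3 (0.03 log units; within the scatter)), so the two halogens cannot be told apart here. The change from 3,4-dimethoxyphenyl now reads beyond the scatter for a second halogen (the step is a 2.1-fold lower number from compound 1 to compound 3 (0.33 log units; beyond the scatter)), as it did for 4-bromophenyl (the step is a 2.3-fold lower number from compound 1 to compound 2 (0.36 log units; beyond the scatter)), so that shift does not rest on bromo alone. Nothing at hand bears on why the numbers fall as they do.

Open, as far as these compounds go, is whether a halogen is needed at all, since fluoro, a single methoxy or a plain phenyl would test that. Also open, from the compounds shown here alone, is whether the 4-chlorobenzyl result carries over to a longer chain or to an amide in place of the amine.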